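Replacing 4-methylphenyl in compound 3 with 2,3-dimethoxyphenyl

This account rests on a few compounds, and the source may have more. Where it says the series, first, only, none or still open, it means among the compounds named here.

Compound 1 `OC[C@H]1O[C@@H](n2cnc3c(NCc4cccc(F)c4)ncnc32)[C@H](O)[C@@H]1O`: 920 nM
Compound 2 `OC[C@H]1O[C@@H](n2cnc3c(NCc4cccc(Br)c4)ncnc32)[C@H](O)[C@@H]1O`: 8000 nM
Compound 3 `Cc1ccc(CNc2ncnc3c2ncn3[C@@H]2O[C@H](CO)[C@@H](O)[C@H]2O)cc1`: > 166000 nM, a limit of the assay

All three compounds were tested in a functional assay on HL-60 cells (Homo sapiens) for antiproliferative activity, with a stated time of 72 h; a higher number here means a weaker inhibitor, a lower number a stronger inhibitor. Compound 3 stands at the weak end of the three, and its result is a limit, not a number. The unmeasured compound 4 `COc1cccc(CNc2ncnc3c2ncn3[C@@H]2O[C@H](CO)[C@@H](O)[C@H]2O)c1OC` carries 2,3-dimethoxyphenyl in place of 4-methylphenyl on a saturated chain carbon bound to a nitrogen on an aromatic ring. Two measured exchanges at this place bear on it, both large: an at least 180-fold higher number from compound 1 to compound 3 (2.25 log units; beyond the scatter) and an at least 20-fold higher number from compound 2 to compound 3 (1.31 log units; beyond the scatter). The exchange an 8.7-fold higher number from compound 1 to compound 2 (0.94 log units; beyond the scatter) is modest by comparison. A clear step toward a lower number is therefore expected in this assay, and the estimated step is an at least 5.5-fold lower number from compound 3 to compound 4 (0.74 log units; beyond the scatter). Compound 4 is expected at 30000 nM, with an estimated range from 4000 nM to 166000 nM.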

Compound 4, half-maximal inhibitory concentration: > 166000 nM
Compound 4 ended at the assay's limit (the forecaster's own chance of this, stated with the estimate: 35%); middle value at least 5.5-fold (0.74 log units) away from the limit.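

In this assay, compound 4 ends at a limit, as compound 3 does, so the step between them cannot be read: the limit of > 166000 nM in this assay, at which 2 of the 4 values shown sit.

Replacing either halogen-bearing ring with 2,3-dimethoxyphenyl costs much, with an at least 180-fold higher number from compound 1 to compound 4 (2.25 log units; beyond the scatter) and an at least 20-fold higher number from compound 2 to compound 4 (1.31 log units; beyond the scatter). Among the compounds shown, only 3-fluorophenyl and 3-bromophenyl give a measured number at this place, while neither group without a halogen does.

Still open, from the compounds shown here alone, is whether a 3-methoxyphenyl or 3-chlorophenyl group here would give a number short of the limit.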